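The source may hold more compounds than are shown below. What is called first, only, known or untested is meant among the compounds shown, and "the series" means these compounds.

Compound 1 `COc1ccc(C2N=C(SCc3ccc(Cl)cc3)NC(C)=C2C(=O)Nc2ccc(F)cc2)cc1OC` and compound 2 `CC1=C(C(=O)Nc2ccc(F)cc2)C(c2ccc([N+](=O)[O-])cc2)N=C(SCc2ccc(Cl)cc2)N1` share one core and differ only on the saturated ring carbon; in a functional assay on the whole organism (artery, strain albino) with Rattus norvegicus as the target, with a stated time of 720 min, at a dose of 10 mg/kg by the oral route (on this read-out lower numbers stand for less inhibition and higher numbers for more inhibition at the one dose given (going by the name of the read-out)), compound 1 gives 22.2% and compound 2 gives 22.2%, so no change at the digits printed from compound 1 to compound 2 (within the scatter). Within the data shown here, compound 3 `CC1=C(C(=O)Nc2ccc(Br)cc2)C(c2ccc(Cl)cc2Cl)N=C(SCc2ccccc2)N1` gives 11.3% in this assay, the lowest of the three numbers; the values of compound 1 and compound 2 both lie above that of compound 3 by more than the scatter, but compound 3 differs from each of them in several places at once, so no single step is defined there. Compound 4 `CC1=C(C(=O)Nc2ccc(Br)cc2)C(c2ccc(Cl)cc2Cl)N=C(SCc2ccccc2Cl)N1` follows compound 3 by one change: chloro in place of hydrogen on an aromatic carbon. Among the measured compounds shown here, no measured step touches the benzylsulfanyl group, so nothing bears directly on this change; the only single-place step available, on the saturated ring carbon, stayed within the scatter. For the measured compounds named here, with no bearing precedent, the step from compound 3 to compound 4 is expected to be of no size beyond the scatter, a number 0.7 percentage points higher from compound 3 to compound 4 (within the scatter). Compound 4 is therefore estimated at 12% in this assay, with a range from 0% to 28%.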

Compound 4, a percentage reported as inhibition, in the whole organism at one dose (the size of the read-out at that dose, not a potency): 20.6%
Compound 4: the middle estimate sits 8.6 percentage points below what was measured; the measured number falls inside the stated range.
By their numbers in this assay, from the lowest: compounds 3, 4, 1 and 2 (each within the scatter of the next, the first and the last beyond it).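

In this assay, among these compounds, the change from benzylsulfanyl to (2-chlorobenzyl)sulfanyl gives a number 9.3 percentage points higher from compound 3 to compound 4 (within the scatter) and is the first single-place step read at this group, since the earlier step concerned only the saturated ring carbon. A chloro on this aromatic carbon, ortho to a large group, is therefore accepted on the core of compound 4 without a step beyond the scatter. No supporting measurement bears on the origin of this step.

On these data alone, whether a methoxy group, an amine or a carboxylic acid at this same place would give a step beyond the scatter remains open. Also open, as far as these compounds go, is how a longer chain in place of the benzyl group would read in this assay on this core.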